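The source may report more compounds than this note shows. Statements on the series, on what has been measured and on what is new or still open speak of the compounds shown alone.

Measured compounds:
compound 1 `CC(C)(C)c1ccc(-n2nc(-c3ccc(C(F)(F)F)cc3O)nc2-c2ccccc2O)cc1`: 81.1%
compound 2 `COc1ccc(-n2nc(-c3ccc(C(F)(F)F)cc3O)nc2-c2ccccc2O)cc1`: 98.9%
compound 3 `Oc1cc(C(F)(F)F)ccc1-c1nc(-c2ccccc2O)n(-c2ccccc2Cl)n1`: 102%

In a functional assay on PC-12 cells (Rattus norvegicus) for cytotoxicity, read by MTT assay, with stated times of 2 h and 24 h, tested at 10 uM (a higher number here means a stronger effect of the compound at the concentration tested, a lower number a weaker effect), compound 1 gives 81.1% and stands lowest of the three numbers; compound 2 gives 98.9% and compound 3 gives 102%, both beyond the scatter above compound 1.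

Compound 4 `Oc1cc(C(F)(F)F)ccc1-c1nc(-c2ccccc2O)n(-c2cccc(Cl)c2)n1` differs from compound 1 in one place: 3-chlorophenyl in place of 4-(tert-butyl)phenyl on an aromatic nitrogen. The step that bears on it most is a number 20.9 percentage points higher from compound 1 to compound 3 (beyond the scatter), which puts a chlorophenyl group on the same aromatic nitrogen. The step of a number 3.1 percentage points higher from compound 2 to compound 3 (within the scatter) shows that once the tert-butyl group is gone, further change of the group on that nitrogen stayed within the scatter. A modest rise in this assay is therefore expected for compound 4, about a number 16.9 percentage points higher from compound 1 to compound 4 (beyond the scatter). Compound 4 is estimated at 98%, within 85% to 108%.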

Compound 4, a percentage reported as activity, at one concentration (the size of the read-out at that concentration, not a potency): 100%
The estimate for compound 4 lay 2 percentage points below the measured number, and the stated range covers the measured number.
By their numbers in this assay, from the lowest: compound 1; then compounds 2, 4 and 3 (each within the scatter of the next).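

In this assay, 3-chlorophenyl in place of 4-(tert-butyl)phenyl on the aromatic nitrogen gives a number 18.9 percentage points higher from compound 1 to compound 4 (beyond the scatter) and adds a third group there, after 4-methoxyphenyl and 2-chlorophenyl, that differs from the 4-(tert-butyl)phenyl result beyond the scatter. The place of the chlorine on the phenyl group does not register, with a number 2 percentage points lower from compound 3 to compound 4 (within the scatter) as the step, and 3-chlorophenyl cannot be told apart from 4-methoxyphenyl, with a number 1.1 percentage points higher from compound 2 to compound 4 (within the scatter) as the step. Nothing available explains these readings.

As far as these compounds go, it remains open whether a phenyl group carrying an amine or a carboxylic acid on that nitrogen would read like compound 4. From the compounds shown here alone, the part played by the two hydroxyl groups of the shared core also remains open.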